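This account rests on a few compounds, and the source may have more. Where it says the series, first, only, none or still open, it means among the compounds named here.

In a functional assay on A549 cells (Homo sapiens) for antiproliferative activity, read by MTT assay, with a stated time of 72 h (on this read-out lower numbers stand for stronger inhibition and higher numbers for weaker inhibition), compound 1 `Nc1ccccc1NC(=O)CCCCCCc1nc(-c2ccc(Cl)cc2)no1` gives 13800 nM. Compound 2 `Nc1ccccc1NC(=O)CCCCCCc1nc(-c2ccc([N+](=O)[O-])cc2)no1` gives only a limit of the assay, > 100000 nM, and not a true number. Going by the values given here, the single measured step, nitro in place of chloro on an aromatic carbon, is an at least 7.2-fold higher number from compound 1 to compound 2 (0.86 log units; beyond the scatter). Compound 3 `Nc1ccccc1NC(=O)CCCCCCc1nc(-c2cccc([N+](=O)[O-])c2)no1` keeps the nitro group but carries 3-nitrophenyl in place of 4-nitrophenyl, on an aromatic carbon of the five-membered ring (3-nitrophenyl in place of 4-nitrophenyl on an aromatic carbon). Among the compounds with values here, no measured step shows what moving a group on this phenyl ring does. The nitro group remains in compound 3, so the weak result seen with an at least 7.2-fold higher number from compound 1 to compound 2 (0.86 log units; beyond the scatter) is expected to largely persist, with at most a modest shift toward stronger inhibition, and another limit is quite possible. That means an estimated at least 1.4-fold lower number from compound 2 to compound 3 (0.15 log units; that floor lies within the scatter). Compound 3 is expected at about 70000 nM, within an estimated range of 20000 nM to 150000 nM.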

Compound 3, half-maximal inhibitory concentration: 20200 nM
The estimate for compound 3 lay 3.5-fold (0.54 log units) above the measured number, and the stated range covers the measured number.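

In this assay, the place of the nitro group on the phenyl ring matters, not just its presence: 3-nitrophenyl in place of 4-nitrophenyl gives an at least 4.9-fold lower number from compound 2 to compound 3 (0.69 log units; beyond the scatter). Going by these compounds, the reading for compound 2 is a limit and not a true number, so the full size of this step remains unknown: the limit of > 100000 nM in this assay, at which 1 of the 3 values shown sits. Set against the 4-chlorophenyl group, the 3-nitrophenyl group shows a 1.5-fold higher number from compound 1 to compound 3 (0.17 log units; within the scatter), so on this evidence a nitro group on this ring does not always come with the weak result seen for compound 2.

The compounds shown leave open whether the chloro group responds in the same way when moved around the ring. They also leave open how an amine or a methoxy group would fare on this ring, and what a longer chain would do.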